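The compounds below may be only part of what the source reports. "The series", "measured", "known", "first", "only" and "open" are said of these compounds alone.

Compound 1, `C/C(=N\NC(=O)Nc1nc2ccc(CN(C)C)cc2s1)c1cnccn1`: in a functional assay on MCF7 cells (Homo sapiens) for antiproliferative activity, read by CCK-8 assay, with a stated time of 24 h (on this read-out higher numbers stand for weaker inhibition and lower numbers for stronger inhibition), compound 1 reaches only the limit of > 40000 nM.
Compound 2, `C/C(=N\NC(=O)Nc1nc2ccc(CN3CCC(C)CC3)cc2s1)c1cnccn1`: in this assay compound 2 gives 11800 nM.
Compound 3, `CN(C)Cc1ccc(NC(=O)N/N=C/c2ccccn2)cc1`: in this assay compound 3 reaches only the limit of > 40000 nM.

Compounds 1 and 2 share one core and differ in a single place: 4-methylpiperidin-1-yl in place of dimethylamino on a saturated chain carbon bound to an aromatic carbon. The step that this change made, an at least 3.3-fold lower number from compound 1 to compound 2 (0.53 log units; beyond the scatter), is the only one in the set that can be sized, and its size is itself open at one end, since the value of compound 1 is a limit and not a number. That two of the three measured values sit at the same limit, (the limit of > 40000 nM in this assay, at which 2 of the 3 values shown sit), leaves little room for comparing compounds 1 and 3 with each other; the difference between the core of compound 1 and the core of compound 3 is not broken down here.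

Compound 4, `CC1CCN(Cc2ccc(NC(=O)N/N=C/c3ccccn3)cc2)CC1`, carries the same change on the core of compound 3: 4-methylpiperidin-1-yl in place of dimethylamino on a saturated chain carbon bound to an aromatic carbon. The place is the same in both pairs, a saturated chain carbon bound to an aromatic carbon, so the change is the same one, made on a different core. The step it made in the first pair rests on a limit, so only its direction and a lower bound on its size are known. The step expected from compound 3 to compound 4 is an at least 2.6-fold lower number from compound 3 to compound 4 (0.42 log units; beyond the scatter), which rests on an at least 3.3-fold lower number from compound 1 to compound 2 (0.53 log units; beyond the scatter). Compound 4 is therefore expected to give about 15000 nM, with the likely range running from 5000 nM to 40000 nM, and a fair chance that the assay again reports only a limit.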

Compound 4, half-maximal inhibitory concentration: > 40000 nM
Compound 4: only a limit was reported (the forecaster's own chance of this, stated with the estimate: 35%); at least 2.6-fold (0.42 log units) between middle value and limit.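

In this assay compound 4 reaches > 40000 nM as a limit and not a number. Compound 3 stands at a limit too, so no step can be read from compound 3 to compound 4: the limit of > 40000 nM in this assay, at which 3 of the 4 values shown sit. The compounds shown leave open whether 4-methylpiperidin-1-yl in place of dimethylamino gives a lower number on the core of compound 3, as it does on the core of compound 1.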